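From compound 3 to compound 4: ethyl gives way to hydrogen

This account rests on a few compounds, and the source may have more. Where it says the series, first, only, none or still open, it means among the compounds named here.

Measured in a toxicity assay on MRC5 cells (Homo sapiens) for inhibition, read by MTT assay, with a stated time of 72 h; on this read-out lower numbers stand for stronger inhibition and higher numbers for weaker inhibition:
- compound 1 `CCCCCCCCCC(=O)OCCc1ccc(O)cc1`: 172000 nM
- compound 2 `CCCCCCCCCCC(=O)OCCc1ccc(O)c(O)c1`: > 50000 nM
- compound 3 `CCCCCCCCCCCC(=O)OCCc1ccc(O)c(O)c1`: 38100 nM

The value of compound 2, > 50000 nM, is a limit and not a number. Of the two true numbers, compound 3 holds the lower at 38100 nM, while compound 1 gives the higher at 172000 nM.

Compound 4 `CCCCCCCCCC(=O)OCCc1ccc(O)c(O)c1` has not yet been measured. Its difference from compound 3 is hydrogen in place of ethyl on a saturated chain carbon, nine bonds along the chain from a carbonyl carbon, which puts hydrogen in place of ethyl on a saturated chain carbon, nine bonds along the chain from a carbonyl carbon.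

For the measured compounds named here, one measured step bears on this change: an at least 1.3-fold lower number from compound 2 to compound 3 (0.11 log units; that floor lies within the scatter). That step adds methyl in place of hydrogen, whereas the change to compound 4 removes ethyl, so it points the opposite way and only loosely. A higher number than that of compound 3 is therefore expected, by a modest step that may only just clear the scatter. Compound 4 may well end at the limit of > 50000 nM in this assay, at which 1 of the 3 values shown sits.

The estimate means an expected 2.2-fold higher number from compound 3 to compound 4 (0.35 log units; beyond the scatter). For compound 4 the estimated value in this assay is 85000 nM, with an expected range from 40000 nM to 200000 nM.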

Compound 4, half-maximal inhibitory concentration: 71100 nM
Beside the measured number, compound 4's estimate is 1.2-fold (0.08 log units) above it; measured number inside the range.
By their numbers in this assay, from the lowest: compounds 3 and 4 (each within the scatter of the next); then compound 1.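

In this assay, for the compounds shown here, hydrogen in place of ethyl on a saturated chain carbon, nine bonds along the chain from a carbonyl carbon, gives a 1.9-fold higher number from compound 3 to compound 4 (0.27 log units; within the scatter), so at this position the change does not separate the two compounds, and the earlier compounds offered no step between two true numbers that could show this. Going by these compounds alone, compound 4 also gives the only readable comparison for hydroxy in place of hydrogen on an aromatic carbon, with the chain held the same: a 2.4-fold lower number from compound 1 to compound 4 (0.38 log units; beyond the scatter), and this step, unlike the chain change, clears the scatter. The step between compound 2 and compound 4 cannot be read, as compound 2 carries a limit and not a number: the limit of > 50000 nM in this assay, at which 1 of the 4 values shown sits.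

With only two true numbers along the chain series, the compounds shown do not settle whether the number in this assay follows chain length at all, or whether a longer chain than that of compound 3 would move it beyond the scatter. They also leave open whether the step from compound 1 to compound 4 would hold with a methoxy in place of the added hydroxy, or with an amide in place of the ester.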